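Swapping the group on the ring nitrogen of compound 3

This account rests on a few compounds, and the source may have more. Where it says the series, first, only, none or still open, it means among the compounds named here.

Measured so far:
Compound 1 `C/N=C(\S)n1nc(-c2ccccc2)nc1N`: 54%
Compound 2 `C/N=C(\S)n1nc(-c2ccc(C)cc2)nc1N`: 65%
Compound 3 `CCOC(=O)C(=O)Nc1ccc(-c2nc(N)n(/C(S)=N/C)n2)cc1`: 49%

All three compounds were tested in a functional assay on the whole organism for inhibition, with Rattus norvegicus as the target, at a dose of 30 mg/kg; a lower number here means less inhibition, a higher number more inhibition at the dose given (going by the name of the read-out). Compound 3 gives the lowest of the three numbers; one of the two steps that end at it is a number 5 percentage points lower from compound 1 to compound 3 (within the scatter), which is within the scatter, while the other is a number 16 percentage points lower from compound 2 to compound 3 (beyond the scatter), which is beyond it. The unmeasured compound 4 `C/N=C(\S)Nc1ccc(-c2nc(N)n(/C(S)=N/C)n2)cc1` keeps the shared core and differs from compound 3 only at the nitrogen on the aromatic ring: a group of 4 heavy atoms (2 carbon, 1 nitrogen, 1 sulfur; no ring) in place of a group of 7 heavy atoms (4 carbon, 3 oxygen; no ring), on a nitrogen on an aromatic ring.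

Among the measured compounds shown here, none of the measured steps changes the group on that nitrogen; the known steps, a number 11 percentage points higher from compound 1 to compound 2 (beyond the scatter) and a number 16 percentage points lower from compound 2 to compound 3 (beyond the scatter), all concern the aromatic carbon, so they set the range of numbers seen rather than the direction of this change. For the measured compounds named here, the group that enters is smaller than the one that leaves, but the data give no step of this kind to lean on. For compound 4 the expected step is therefore a number 5 percentage points higher from compound 3 to compound 4 (within the scatter), a change not clearly beyond the scatter. Compound 4 is thus estimated at 54%, with a range from 38% to 70%.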

Compound 4, a percentage reported as inhibition, in the whole organism at one dose (the size of the read-out at that dose, not a potency): 31%
The estimate for compound 4 lay 23 percentage points above the measured number; measured number below the stated range.
By their numbers in this assay, from the lowest: compound 4; then compounds 3 and 1 (each within the scatter of the next); then compound 2.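

The group on the nitrogen on the aromatic ring does affect the result in this assay: with a smaller group in place of (ethoxycarbonyl)carbonyl, the change is a number 18 percentage points lower from compound 3 to compound 4 (beyond the scatter), the only step shown at this nitrogen. The wider change on the aromatic carbon gives a clearer drop, with a number 23 percentage points lower from compound 1 to compound 4 (beyond the scatter) and a number 34 percentage points lower from compound 2 to compound 4 (beyond the scatter), which makes compound 4 the lowest of the four, whereas compound 3 stayed within the scatter of compound 1. No measurement shown here accounts for this drop.

On these data alone, it remains open whether the sulfur-containing part of the new group matters or whether the loss of (ethoxycarbonyl)carbonyl alone explains the result. A free amine or a simple acetyl group on that nitrogen would help separate these two readings.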